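The compounds below may be only part of what the source reports. "The series", "measured", "known", "first", "only" and "open" are said of these compounds alone.

Measured so far:
compound 1, `CC(C)[C@H](C)NC(=O)c1ccc(C#Cc2cccc(F)c2)cn1`: 66.7%
compound 2, `O=C(NCC1CCC1)c1ccc(C#Cc2cccc(F)c2)cn1`: 68.1%

Both compounds were tested in a functional assay on HEK293 cells for positive allosteric modulation of metabotropic glutamate receptor 5 (Rattus norvegicus), read by fluorescence and calcium flux; on this read-out lower numbers stand for smaller maximal responses and higher numbers for larger maximal responses. For the measured compounds named here, compound 2 gives the higher of the two numbers with 68.1%, but the only measured step, a number 1.4 percentage points higher from compound 1 to compound 2 (within the scatter), lies within the scatter, so the two compounds cannot be told apart on this read-out.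

Compound 3, `CC(C)(O)CNC(=O)c1ccc(C#Cc2cccc(F)c2)cn1`, has not yet been measured. It differs from compound 2 in one place: 1-hydroxy-1-methylethyl in place of cyclobutyl on a saturated chain carbon bound to an amide-type nitrogen.

Going by the values given here, the single measured step, a number 1.4 percentage points higher from compound 1 to compound 2 (within the scatter), shows that exchanging the group on the amide-type nitrogen left the maximal response unchanged beyond the scatter. Among the compounds with values here, that step, however, exchanged one ring-free or ring-bearing carbon group for another; no measured compound carries a hydrogen-bond donor or acceptor at this place, so nothing measured bears directly on the entering group. With no evidence for a change, a step of about a number 3.1 percentage points lower from compound 2 to compound 3 (within the scatter) is expected, with a wide range to allow for the untested group.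

Compound 3 is therefore estimated to give 65%, with a range from 45% to 85%.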

Compound 3, largest response reached (reported as efficacy), in percent of the reference or control that the assay uses: 61.5%
The estimate for compound 3 lay 3.5 percentage points above the measured number; the measured number falls inside the stated range.
By their numbers in this assay, from the lowest: compounds 3, 1 and 2 (each within the scatter of the next).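

For the compounds shown here, compound 3 brings something the earlier compounds lacked at this place: 2-hydroxy-2-methylpropyl on the amide-type nitrogen, a group without a ring that counts one hydrogen-bond donor and one hydrogen-bond acceptor. In this assay, replacing cyclobutylmethyl with this group gives a number 6.6 percentage points lower from compound 2 to compound 3 (within the scatter), and replacing 1,2-dimethylpropyl with it gives a number 5.2 percentage points lower from compound 1 to compound 3 (within the scatter), so neither exchange separates the compounds, and a hydroxyl-bearing group is accommodated here without a change in maximal response beyond the scatter. The data shown offer no measurement that would explain this outcome.

Still open, on these data alone, is whether the result depends on the hydroxyl itself: an amine or a carboxylic acid on the same chain, a methoxy group in place of the hydroxyl, or a longer chain carrying the hydroxyl could each behave differently. Because this assay reports only the largest response reached, these three compounds also leave open how much of each is needed to produce that response.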